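Working notes on a small set: bromo in place of hydrogen

The source may hold more compounds than are shown below. What is called first, only, known or untested is meant among the compounds shown, and "the series" means these compounds.

Measured so far in a functional assay on Ehrlich cells (Mus musculus) for cytotoxicity, read by LDH release, with a stated time of 48 h; on this read-out higher numbers stand for weaker inhibition and lower numbers for stronger inhibition:
Compound 1 `COc1ccc(C(=O)c2cc(C)ccc2OCC(=O)NNC(=O)c2cc3ccccc3oc2=O)cc1`: 41200 nM
Compound 2 `Cc1ccc(OCC(=O)NNC(=O)c2cc3ccccc3oc2=O)c(C(=O)c2ccccc2Br)c1`: 9400 nM
Compound 3 `Cc1ccc(OCC(=O)NNC(=O)c2cc3ccccc3oc2=O)c(C(=O)c2ccccc2)c1`: 81100 nM

Compound 3 stands highest of the three numbers. Its nearest neighbour is compound 1, a 2.0-fold higher number from compound 1 to compound 3 (0.29 log units; within the scatter), so these two cannot be ordered. Compound 2 lies furthest away, an 8.6-fold higher number from compound 2 to compound 3 (0.94 log units; beyond the scatter).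

Compound 4 `Cc1ccc(OCC(=O)NNC(=O)c2cc3ccccc3oc2=O)c(C(=O)c2cccc(Br)c2)c1` follows from compound 3 by one change: bromo in place of hydrogen on an aromatic carbon. The change sits on a six-membered aromatic ring of carbon only, meta to a large group.

Among the compounds with values here, the step that bears on this is the one between compound 2 and compound 3, an 8.6-fold higher number from compound 2 to compound 3 (0.94 log units; beyond the scatter), where the same bromo was removed from an aromatic carbon of the same ring, though at a different place. Compound 1 against compound 2, a 4.4-fold lower number from compound 1 to compound 2 (0.64 log units; beyond the scatter), also involves a bromo entering at an aromatic carbon together with a change elsewhere, and points the same way. Within the data shown here, no step tests the place occupied in compound 4, so the size seen between compound 2 and compound 3 is taken as an upper guide rather than a prediction.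

A lower number than that of compound 3 is therefore expected for compound 4, beyond the scatter but likely smaller than an 8.6-fold higher number from compound 2 to compound 3 (0.94 log units; beyond the scatter). The expected step is a 3.7-fold lower number from compound 3 to compound 4 (0.57 log units; beyond the scatter). Compound 4 is estimated at 22000 nM, with a range from 7000 nM to 60000 nM.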

Compound 4, half-maximal inhibitory concentration: 68100 nM
For compound 4 the middle estimate is 3.1-fold (0.49 log units) below the measured one; the measured number lies above the stated range.
By their numbers in this assay, from the lowest: compound 2; then compounds 1, 4 and 3 (each within the scatter of the next).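

In this assay adding the bromo at this place gives no readable change (a 1.2-fold lower number from compound 3 to compound 4 (0.08 log units; within the scatter)), so a bromo on this ring does not by itself carry the difference seen with compound 2. Within this set the place on the ring matters: 3-bromophenyl in place of 2-bromophenyl gives a step beyond the scatter (a 7.2-fold higher number from compound 2 to compound 4 (0.86 log units; beyond the scatter)), comparable in size to that from removing the bromo altogether (an 8.6-fold higher number from compound 2 to compound 3 (0.94 log units; beyond the scatter)). The 3-bromophenyl and 4-methoxyphenyl groups cannot be ordered (a 1.7-fold higher number from compound 1 to compound 4 (0.22 log units; within the scatter)), which leaves compound 2 as the only one of the four that stands apart from the others.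

No measurement at hand accounts for the difference between the two bromo places. As far as these compounds go, it also remains open whether the separation of compound 2 belongs to bromo specifically or to any group at that place on the ring, a question that chloro, methyl or an amine there would address, and whether a larger group such as a carboxylic acid at the place held by bromo in compound 4 would also leave the number unchanged.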